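The compounds below may be only part of what the source reports. "The series", "measured", "known", "first", "only" and "open" are said of these compounds alone.

Of the compounds shown here, two built on a shared core have so far been measured in an assay on lysosomes for inhibition of Maltase-glucoamylase (Homo sapiens), read by spectrophotometry, tested at 1000 uM; a higher number here means more inhibition at the concentration tested (going by the name of the read-out), a lower number less inhibition. Compound 1, `O[C@H]1[C@H](CCCc2ccccc2)NC[C@@H]1O`, gives 27.8% in this assay. Compound 2, `O[C@@H]1[C@@H](O)CN[C@H]1c1ccccc1`, gives 24.6% in this assay. On these two numbers compound 2 does not stand apart: its nearest neighbour is compound 1, and the gap between them lies within the scatter of repeated measurements of this kind, so nothing can be read into which of the two sits where.

The account now turns to compound 3, `O[C@@H]1[C@@H](O)CN[C@H]1c1ccc(F)cc1`, which differs from compound 2 in a single place: fluoro in place of hydrogen on an aromatic carbon. For the measured compounds named here, no measured pair in this set shows what such a change does, so there is no step to lean on, and the only guide is that the two measured compounds sit close together in this assay. The step expected a number 0.4 percentage points higher from compound 2 to compound 3 (within the scatter) is therefore estimated to be small, in no firm direction, and not beyond the scatter. The estimate for compound 3 in this assay is 25%, with a range from 10% to 42%.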

Compound 3, a percentage reported as inhibition, at one concentration (the size of the read-out at that concentration, not a potency): 30%
Estimate against measurement, compound 3: 5 percentage points below; measured number inside the range.
By their numbers in this assay, from the lowest: compounds 2, 1 and 3 (each within the scatter of the next).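

For the compounds shown here, this is the first reading of what a change on the aromatic ring does: fluoro in place of hydrogen on an aromatic carbon, para to a group of 7 heavy atoms, gives a number 5.4 percentage points higher from compound 2 to compound 3 (within the scatter) in this assay. The position therefore accepts a single fluoro without a shift that can be told apart from the scatter, and this one step gives no firm direction for the change. Nothing measured here bears on why the number stays so close to that of the unsubstituted ring.

What the compounds shown leave open is whether a larger or different group at the same position, such as chloro, methoxy, an amine or a carboxylic acid, would move the reading beyond the scatter in either direction. Going by these compounds, it is also open whether fluoro in place of hydrogen on the aromatic ring of compound 1, which carries a longer chain, would give a step of similar size.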